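Methoxy Added to a Pyrazoline Phenyl: Expected Outcome

This account rests on a few compounds, and the source may have more. Where it says the series, first, only, none or still open, it means among the compounds named here.

Measured compounds:
- compound 1 `COc1ccc(C2CC(c3ccccc3)=NN2c2nc(-c3ccc(Cl)cc3)c(C#N)c(=O)n2C)cc1` gives 19500 nM in a functional assay on MDA-MB-231 cells (Homo sapiens) for antiproliferative activity, with a stated time of 72 h; a lower number here means a stronger inhibitor, a higher number a weaker inhibitor
- compound 2 `Cn1c(N2N=C(c3ccc(Cl)cc3)CC2c2ccccc2)nc(-c2ccc(Cl)cc2)c(C#N)c1=O` gives 12400 nM in this assay

Compound 2 stands beside compound 1 on the numbers shown: the two values lie within the usual scatter of each other, so nothing separates them, and no step between two measured compounds differing in one place is available.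

Compound 3 `COc1ccc(C2CC(c3ccc(Cl)cc3)=NN2c2nc(-c3ccc(Cl)cc3)c(C#N)c(=O)n2C)cc1` differs from compound 2 by methoxy in place of hydrogen on an aromatic carbon. The new group sits on an aromatic carbon of a six-membered aromatic ring of carbon only, para to a large group; one bond further out, the change reads phenyl to 4-methoxyphenyl.

Among the compounds with values here, with no measured step for this change, the expectation for this assay is no movement beyond the scatter. Compound 3 is therefore estimated at 12000 nM, with a range from 5000 nM to 30000 nM. The step from compound 2 expected in this way is a 1.0-fold lower number from compound 2 to compound 3 (0.01 log units; within the scatter).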

Compound 3, half-maximal inhibitory concentration: 24800 nM
Estimate against measurement, compound 3: 2.1-fold (0.32 log units) below; low and high end bracket the measured number.
By their numbers in this assay, from the lowest: compounds 2, 1 and 3 (each within the scatter of the next).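

Methoxy in place of hydrogen on an aromatic carbon, para to a large group, gives a 2.0-fold higher number from compound 2 to compound 3 (0.30 log units; within the scatter) in this assay and so provides the first reading of this change, which stays within the scatter on this core. Chloro in place of hydrogen on an aromatic carbon gives a 1.3-fold higher number from compound 1 to compound 3 (0.10 log units; within the scatter) and also stays within the scatter, so neither single change separates the compounds in this set. No measurement shown here bears on what lies behind these two readings.

Hydrogen and methoxy are the only groups shown at this place, so it remains open whether an amine, a carboxylic acid or a longer chain such as butoxy would move the number beyond the scatter. The chloro step also rests on one pair, leaving open how bromo or methyl would read there.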